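From 1,3-thiazol-5-yl to thiophen-3-yl on a shared core

The source may report more compounds than this note shows. Statements on the series, on what has been measured and on what is new or still open speak of the compounds shown alone.

Compound 1 (`CCCCCCCCCCCC[C@@H](O)[C@H]1CC[C@H]([C@H](O)CCCCCCCCCCNC(=O)c2ccco2)O1`), compound 2 (`CCCCCCCCCCCC[C@@H](O)[C@H]1CC[C@H]([C@H](O)CCCCCCCCCCNC(=O)c2ccoc2)O1`) and compound 3 (`CCCCCCCCCCCC[C@@H](O)[C@H]1CC[C@H]([C@H](O)CCCCCCCCCCNC(=O)c2cncs2)O1`) share one core and differ only in the ring on a carbonyl carbon. In a functional assay on NCI-H460 cells (Homo sapiens) for inhibition, read by colorimetric assay and sulforhodamine B assay, with a stated time of 48 h (on this read-out lower numbers stand for stronger inhibition of growth and higher numbers for weaker inhibition of growth), compound 1 gives 18200 nM, compound 2 gives 100000 nM and compound 3 gives 34700 nM. Compound 3 therefore sits with compound 1, as the measurements show a 1.9-fold higher number from compound 1 to compound 3 (0.28 log units; within the scatter). Compound 2 stands apart, with a 2.9-fold lower number from compound 2 to compound 3 (0.46 log units; beyond the scatter).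

The next member is compound 4 (`CCCCCCCCCCCC[C@@H](O)[C@H]1CC[C@H]([C@H](O)CCCCCCCCCCNC(=O)c2ccsc2)O1`), which has thiophen-3-yl in place of 1,3-thiazol-5-yl on a carbonyl carbon. Among the measured compounds shown here, no measured compound carries thiophen-3-yl, so the evidence is indirect. The closest measured relative is the furan-3-yl ring of compound 2, which showed a 5.5-fold higher number from compound 1 to compound 2 (0.74 log units; beyond the scatter). For the measured compounds named here, that step and the one to compound 3 are both modest, so a ring swap here has not yet moved the number far. A small rise in this assay seems possible, but no step beyond the scatter is expected, and the estimated change is a 1.3-fold higher number from compound 3 to compound 4 (0.11 log units; within the scatter). For compound 4 the expected value is 45000 nM, with an estimated range from 18000 nM to 100000 nM.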

Compound 4, concentration for 50% growth inhibition: 4900 nM
Compound 4: the middle estimate sits 9.2-fold (0.96 log units) above what was measured; the whole stated range lies above it.
By their numbers in this assay, from the lowest: compound 4; then compounds 1 and 3 (each within the scatter of the next); then compound 2.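

Among the compounds shown here, this position on the carbonyl carbon proves more sensitive than the earlier compounds suggested: in this assay, exchanging one five-membered aromatic ring for another with the same number of heavy atoms gives a 7.1-fold lower number from compound 3 to compound 4 (0.85 log units; beyond the scatter) and leaves compound 4 with the lowest number of the four. For the compounds shown here, the comparison with the furan rings is sharper still, with a 3.7-fold lower number from compound 1 to compound 4 (0.57 log units; beyond the scatter) and, the only large step so far, a 20-fold lower number from compound 2 to compound 4 (1.31 log units; beyond the scatter) for a change that replaces the ring oxygen with sulfur. Sulfur alone does not set the order, however, since compound 3 also carries it and its number stays within the scatter of that of compound 1, so the gain belongs to the thiophen-3-yl ring of compound 4 rather than to every sulfur-containing ring shown here.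

The data shown offer no measurement that explains why these rings differ. Going by these compounds, it also remains open whether a methyl group or a chlorine atom on the thiophen-3-yl ring would keep, improve or lose the growth inhibition seen with compound 4.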